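Fluorinated aryl on the pyridine core: toward compound 4

The compounds below may be only part of what the source reports. "The series", "measured", "known", "first", "only" and "open" are said of these compounds alone.

Measured compounds in a functional assay on HEK293 cells for agonist activity at 5-hydroxytryptamine receptor 3A (Homo sapiens), read by FLIPR; a lower number here means a stronger inhibitor, a higher number a weaker inhibitor:
- compound 1 `O=C(NCCCCN1CCCCC1)Nc1ccc(-c2ccccc2)cc1`: 7900 nM
- compound 2 `O=C(NCCCCN1CCCCC1)Nc1ccc(-c2ccccn2)nc1`: a limit, > 30000 nM
- compound 3 `O=C(NCCCCN1CCCCC1)Nc1ccc(-c2ccc(F)nc2)nc1`: a limit, > 30000 nM

Compound 3 stands only at a limit in this assay; it gives no number. Compound 2 likewise sits at a limit. For the measured compounds named here, the one step that connects them, a step that the two limits leave unreadable from compound 2 to compound 3, is therefore not readable, and the limit of > 30000 nM in this assay, at which 2 of the 3 values shown sit, marks where two of the three values rest. Going by the values given here, the only number in the set is that of compound 1.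

Compound 4 `O=C(NCCCCN1CCCCC1)Nc1ccc(-c2ccccc2F)nc1` is obtained by the change (2-fluorophenyl in place of 6-fluoropyridin-3-yl on an aromatic carbon). No measured step exchanges a pyridyl for a fluorophenyl, so nothing among the shown steps reads directly onto it; compound 1, with a phenyl on its core, is the closest point of reference, while the pyridine core of compound 4 is shared with compound 3. Compound 4 is expected to be weak, possibly again at the limit, with the step of an at least 1.5-fold lower number from compound 3 to compound 4 (0.17 log units; that floor lies within the scatter) stated only as an expectation. Compound 4 is estimated at 20000 nM, between 6000 nM and 60000 nM.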

Compound 4, half-maximal inhibitory concentration in the 5-hydroxytryptamine receptor 3A assay: > 30000 nM
Compound 4: only a limit was reported; the forecaster's own chance of this, stated with the estimate: 50%; middle value at least 1.5-fold (0.17 log units) away from the limit.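

In the 5-hydroxytryptamine receptor 3A assay compound 4 gives > 30000 nM, which is a limit and not a number. Compound 2 and compound 3 also give only limits in the 5-hydroxytryptamine receptor 3A assay, so no step among these three can be read: the limit of > 30000 nM in the 5-hydroxytryptamine receptor 3A assay, at which 3 of the 4 values shown sit.

In a physicochemical assay for solubility, at pH 7.4 (a higher number here means a more soluble compound, a lower number a less soluble compound), compound 3 gives 205000 nM and compound 4 gives 196000 nM. Between them the physicochemical assay shows a 1.0-fold lower number from compound 3 to compound 4 (0.02 log units; within the scatter), so the two values cannot be told apart.

Still open, as far as these compounds go, is how far the groups carried on the shared core of compound 2, compound 3 and compound 4 differ in the 5-hydroxytryptamine receptor 3A assay.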